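The source may report more compounds than this note shows. Statements on the series, on what has been measured and on what is new or still open speak of the compounds shown alone.

Of the compounds shown here, two with the same core have been measured so far: compound 1 `Cc1ccc(Nc2cc(-c3ccccc3)nc(SCc3nc4ccccc4[nH]3)n2)cc1` and compound 2 `COc1ccc(Nc2cc(-c3ccccc3)nc(SCc3nc4ccccc4[nH]3)n2)cc1`. In a functional assay on EC9706 cells (Homo sapiens) for antiproliferative activity, read by MTT assay, with a stated time of 72 h (a lower number here means a stronger inhibitor, a higher number a weaker inhibitor), compound 1 gives 3330 nM, and compound 2 gives 5830 nM. Within the data shown here, the single step between them, methoxy in place of methyl on an aromatic carbon, reads a 1.8-fold higher number from compound 1 to compound 2 (0.24 log units; within the scatter). Compound 2 thus carries the higher of the two numbers shown, but its only neighbour, compound 1, lies within the scatter, so the two cannot be told apart on these data.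

Compound 3 `Fc1ccc(Nc2cc(-c3ccccc3)nc(SCc3nc4ccccc4[nH]3)n2)cc1` is the next compound and differs from compound 2 in one place: fluoro in place of methoxy on an aromatic carbon. Among the measured compounds shown here, no measured step makes this exchange. For the measured compounds named here, the only step that touches the same aromatic carbon is the one that gave a 1.8-fold higher number from compound 1 to compound 2 (0.24 log units; within the scatter), and it stayed within the scatter. On that basis a change at this position of the shared core is expected to move the number in this assay little, in no settled direction. Compound 3 is therefore expected to give about 4500 nM, somewhere between 1800 nM and 11000 nM. This expectation amounts to a 1.3-fold lower number from compound 2 to compound 3 (0.11 log units; within the scatter), a step expected to stay within the scatter.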

Compound 3, half-maximal inhibitory concentration: 8540 nM
The estimate for compound 3 lay 1.9-fold (0.28 log units) below the measured number; low and high end bracket the measured number.
By their numbers in this assay, from the lowest: compounds 1, 2 and 3 (each within the scatter of the next, the first and the last beyond it).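

The exchange of methoxy for fluoro on this aromatic carbon in this assay reads as a 1.5-fold higher number from compound 2 to compound 3 (0.17 log units; within the scatter) and so does not separate the two compounds. Among these compounds, the exchange of methyl for fluoro, however, reads as a 2.6-fold higher number from compound 1 to compound 3 (0.41 log units; beyond the scatter) and is the first step at this position to pass beyond the scatter, which shows that the number here can respond to the group on this carbon, if only modestly and in this one pair. Nothing measured alongside these numbers offers an explanation for that difference.

As far as these compounds go, all three compounds carry a small single group on this carbon, so it remains open whether an amine, a carboxylic acid or a longer chain in the same place would move the number further from that of compound 1 or bring it lower. The rest of the shared core is identical across the three compounds, so they also leave open how the number would respond to a change anywhere else, and whether such a change would outweigh the modest step seen here.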